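Terpenoid lactone acids: assessing a tert-butyl ester

This account rests on a few compounds, and the source may have more. Where it says the series, first, only, none or still open, it means among the compounds named here.

Measured so far:
compound 1 `CC1(C)[C@@H]2CC3=N[C@@H](CCC(=O)O)C(=O)O[C@@]3(C)[C@H]1C2` gives > 1200000 nM in an ADME assay on NIH3T3 cells (Mus musculus) for antiproliferative activity, read by sulforhodamine B assay, with a stated time of 48 h (on this read-out lower numbers stand for stronger inhibition and higher numbers for weaker inhibition), a limit of the assay.
compound 2 `CC1(C)[C@H]2CC3=N[C@H](CCC(=O)O)C(=O)O[C@]3(C)[C@@H]1C2` gives > 1200000 nM in this assay, a limit of the assay.
compound 3 `CC1(C)[C@@H]2CC3=NCC(=O)O[C@@]3(C)[C@H]1C2` gives > 900000 nM in this assay, a limit of the assay.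

Compound 1 therefore stands only at a limit, as do the other two. The step that the two limits leave unreadable from compound 1 to compound 2 and the step that the two limits leave unreadable from compound 1 to compound 3 are both left unreadable by the limit of > 1200000 nM in this assay, at which 2 of the 3 values shown sit, and (the limit of > 900000 nM in this assay, at which 1 of the 3 values shown sits); compounds 1 and 2 are mirror images (the fact that compounds 1 and 2 differ only in the configuration as drawn), yet neither gives a number. Compound 4 `CC(C)(C)OC(=O)CC[C@@H]1N=C2C[C@@H]3C[C@@H](C3(C)C)[C@]2(C)OC1=O` differs from compound 1 by tert-butyl in place of hydrogen on an oxygen next to a carbonyl group. No measured step bears directly on this change, and the shared core has so far shown nothing but limits. Compound 4 is expected to remain near the limit, a step of a number no higher from compound 1 to compound 4 (the limit leaves the size open) of no readable size; the estimate for compound 4 is 1200000 nM, within 400000 nM to 3000000 nM.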

Compound 4, half-maximal inhibitory concentration: > 1000000 nM
Compound 4: only a limit was reported; the forecaster's own chance of this, stated with the estimate: 80%; the middle value lies beyond the limit too.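

In this assay compound 4 gives > 1000000 nM, a limit of the assay. Among these compounds, compound 1 also stands only at a limit, so no step between compound 1 and compound 4 can be read. The compounds shown leave open whether tert-butyl in place of hydrogen changes activity at all, and whether the shared core can give a measured number in this assay.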